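Removing the benzyloxy group from a stable scaffold

The compounds below may be only part of what the source reports. "The series", "measured", "known", "first", "only" and "open" are said of these compounds alone.

Among the compounds with values here, compound 2, with the structure `CC(C)N1C(=O)C(=O)N=C1/N=C(\NOCc1ccccc1)Nc1ccc(Cl)c(Cl)c1`, is one of two compounds measured in an in vitro ADME assay on microsomes from liver (Mus musculus) for metabolic stability, read by LC-MS; a higher number here means that the compound lasts longer, a lower number that the compound disappears faster. In this assay compound 2 gives > 1 h, which is a limit of the assay rather than a number. Compound 1, with the structure `CON/C(=N\C1=NC(=O)C(=O)N1C(C)C)Nc1ccc(Cl)c(Cl)c1`, is its closest measured neighbour. In this assay compound 1 gives > 1 h, again a limit. Within the data shown here, the only measured step, a step that the two limits leave unreadable from compound 1 to compound 2, is therefore unreadable because of the limit of > 1 h in this assay, at which 2 of the 2 values shown sit.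

Compound 3, with the structure `CN/C(=N\C1=NC(=O)C(=O)N1C(C)C)Nc1ccc(Cl)c(Cl)c1`, differs from compound 2 by methyl in place of benzyloxy on an amine nitrogen. Among the measured compounds shown here, no measured step bears directly on this change, and the two values on record give no direction. Compound 3 is therefore expected to sit near the same limit, with an estimated step that the limit leaves unreadable from compound 2 to compound 3. The half-life of compound 3 is estimated at 1.5 h, within a range from 0.5 h to 4 h.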

Compound 3, half-life: > 1 h
Compound 3: a limit, no number; the forecaster's own chance of this, stated with the estimate: 55%; the middle value lies beyond the limit too.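

No new step can be read from compound 3 against compound 1 or compound 2 in this assay: the limit of > 1 h in this assay, at which 3 of the 3 values shown sit. The compounds shown leave open whether methyl, methoxy and benzyloxy on the amine nitrogen differ at all in this assay.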